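Dimethylcarbamoyl in place of hydroxymethyl: an estimated step

This account rests on a few compounds, and the source may have more. Where it says the series, first, only, none or still open, it means among the compounds named here.

Compound 1, `C[C@H](O)[C@@H](CCc1cccc(F)c1)n1cnc2c(N)ncnc21`: 1.6 nM in an assay on isolated protein for inhibition of adenosine deaminase (Bos taurus), with a stated time of 5 min; on this read-out lower numbers stand for stronger inhibition and higher numbers for weaker inhibition
Compound 2, `C[C@H](O)[C@@H](CCc1cccc(-c2cnccn2)c1)n1cnc2c(N)ncnc21`: 1.9 nM in this assay
Compound 3, `C[C@H](O)[C@@H](CCc1cccc(CO)c1)n1cnc2c(N)ncnc21`: 4.6 nM in this assay

Compound 3 gives the highest number of the three in this assay. Its nearest neighbour is compound 2, with a 2.4-fold higher number from compound 2 to compound 3 (0.38 log units; beyond the scatter), and the furthest is compound 1, with a 2.9-fold higher number from compound 1 to compound 3 (0.46 log units; beyond the scatter); both steps lie beyond the scatter, while a 1.2-fold higher number from compound 1 to compound 2 (0.07 log units; within the scatter) does not.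

Compound 4, `C[C@H](O)[C@@H](CCc1cccc(C(=O)N(C)C)c1)n1cnc2c(N)ncnc21`, has not yet been measured. The change from compound 3 is dimethylcarbamoyl in place of hydroxymethyl on an aromatic carbon; the place is on an aromatic carbon of a six-membered aromatic ring of carbon only; meta to a large group. Among the measured compounds shown here, no measured step introduces dimethylcarbamoyl, so the only bearing steps are those that remove or install hydroxymethyl. Both of those were modest and ran against hydroxymethyl, and the two groups that gave lower numbers than it, fluoro and pyrazin-2-yl, sit within the scatter of each other. On that basis a modest step toward a lower number is expected for compound 4, a 1.8-fold lower number from compound 3 to compound 4 (0.26 log units; within the scatter), with a clear chance of none beyond the scatter. The estimate for compound 4 in this assay is 2.5 nM, ranging from 1 nM to 7 nM.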

Compound 4, inhibition constant: 1.8 nM
Compound 4: the middle estimate sits 1.4-fold (0.14 log units) above what was measured; measured number inside the range.
By their numbers in this assay, from the lowest: compounds 1, 4 and 2 (each within the scatter of the next); then compound 3.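

In this assay, dimethylcarbamoyl in place of hydroxymethyl on this aromatic carbon gives a modest step beyond the scatter (a 2.6-fold lower number from compound 3 to compound 4 (0.41 log units; beyond the scatter)), so a third group now stands apart from hydroxymethyl in the same direction. Compound 4 also stays within the scatter of the other two compounds, both against pyrazin-2-yl (a 1.1-fold lower number from compound 2 to compound 4 (0.02 log units; within the scatter)) and against fluoro (a 1.1-fold higher number from compound 1 to compound 4 (0.05 log units; within the scatter)), so fluoro, pyrazin-2-yl and dimethylcarbamoyl cannot be told apart at this place. This position therefore accepts a group of 5 heavy atoms without a ring, and among the four compounds only hydroxymethyl separates from the rest, though by modest steps.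

On these data alone, what an unsubstituted carbamoyl, a carboxylic acid or an amine would give on this aromatic carbon stays open, and with it whether the hydrogen-bond donor counted on hydroxymethyl has any link to its higher number. Nothing in the material shown gives a measured reason for the step from hydroxymethyl to dimethylcarbamoyl.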